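This account rests on a few compounds, and the source may have more. Where it says the series, first, only, none or still open, it means among the compounds named here.

In a functional assay on A549 cells (Homo sapiens) for cytotoxicity (a higher number here means that more compound is needed for the effect, a lower number that less compound is needed), compound 3 `COC1=C(C)C(=O)/C(=C(O)/C=C/c2ccc(C)cc2)C(=O)C1(C)C` gives 4.3 ug/mL, within the scatter of both compound 1 `COC1=C(C)C(=O)/C(=C(O)/C=C/c2ccc(OC)cc2)C(=O)C1(C)C` at 3 ug/mL and compound 2 `COC1=C(C)C(=O)/C(=C(O)/C=C/c2cccc(OC)c2)C(=O)C1(C)C` at 2.8 ug/mL. Compound 4 `COC1=C(C)C(=O)/C(=C(O)/C=C/c2cccs2)C(=O)C1(C)C` carries thiophen-2-yl in place of 4-methylphenyl on a double-bonded chain carbon bound to a double-bonded chain carbon. The steps bearing on this are a 1.5-fold higher number from compound 2 to compound 3 (0.19 log units; within the scatter), a 1.4-fold higher number from compound 1 to compound 3 (0.16 log units; within the scatter) and a 1.1-fold lower number from compound 1 to compound 2 (0.03 log units; within the scatter), each within the scatter. Going by the values given here, none of the measured compounds carries a five-membered aromatic ring, so these steps are only indirect guides. No step beyond the scatter is expected in this assay, and the estimated step is a 1.2-fold lower number from compound 3 to compound 4 (0.09 log units; within the scatter). Compound 4 is estimated at 3.5 ug/mL, with an expected range of 1.7 ug/mL to 7 ug/mL.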

Compound 4, concentration for half-maximal effect: 4.5 ug/mL
Estimate against measurement, compound 4: 1.3-fold (0.11 log units) below; low and high end bracket the measured number.
By their numbers in this assay, from the lowest: compounds 2, 1, 3 and 4 (each within the scatter of the next).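

At the place on a double-bonded chain carbon bound to a double-bonded chain carbon, thiophen-2-yl brings a five-membered aromatic ring with a sulfur atom, and this assay stays within the scatter of all three six-membered aromatic rings (a 1.0-fold higher number from compound 3 to compound 4 (0.02 log units; within the scatter); a 1.6-fold higher number from compound 2 to compound 4 (0.21 log units; within the scatter); a 1.5-fold higher number from compound 1 to compound 4 (0.18 log units; within the scatter)). The series therefore tolerates this change of ring size and hetero atom content, as far as these four compounds go. No measurement on hand explains this flat reading.

Every compound shown carries an aromatic ring here, so it remains open whether an amine, a carboxylic acid or a longer chain in this place would give a step beyond the scatter.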